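Shifting Two Methyl Groups on a Growth Inhibitor

The compounds below may be only part of what the source reports. "The series", "measured", "known", "first", "only" and "open" are said of these compounds alone.

Three compounds have numbers in a toxicity assay on HUVEC cells (Homo sapiens) for inhibition; a higher number here means a weaker inhibitor of growth, a lower number a stronger inhibitor of growth. Here compound 1 (`Cc1nc(-c2ccccc2)c(C(=O)N2CCN(c3cccc(C)c3C)CC2)o1`) gives 0.38 ug/mL, the middle of the three. Compound 2 (`COc1cc(OC)cc(N2CCN(C(=O)c3oc(C)nc3-c3ccccc3F)CC2)c1`) gives a lower number, 0.118 ug/mL. Compound 3 (`CCC[C@H](Nc1nc(-c2ccc(NC(=O)NCC)c(OC)c2)ncc1C)c1cccnc1`) gives a higher one, 2.1 ug/mL. Both gaps from compound 1 lie beyond the usual scatter of such measurements.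

Compound 4 (`Cc1cc(C)cc(N2CCN(C(=O)c3oc(C)nc3-c3ccccc3)CC2)c1`) has not yet been measured. It has the same atoms as compound 1, joined differently: 3,5-dimethylphenyl stands in place of 2,3-dimethylphenyl on an amine nitrogen in a ring (3,5-dimethylphenyl in place of 2,3-dimethylphenyl on an amine nitrogen in a ring). The rest of the molecule stays the same.

Going by the values given here, no measured pair here differs in only one place, so the data do not show directly what a swap like this does. The best guide is compound 2 at 0.118 ug/mL, which resembles compound 4 more than compound 3 does, yet it differs from compound 1 in more than one place. It therefore suggests only a slight lean toward a lower number. The expected step, a 1.4-fold lower number from compound 1 to compound 4 (0.15 log units; within the scatter), is estimated to stay within the usual scatter. In this assay, the estimate for compound 4 is 0.27 ug/mL, with an expected range from 0.09 ug/mL to 0.8 ug/mL.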

Compound 4, concentration for 50% growth inhibition: 0.356 ug/mL
Beside the measured number, compound 4's estimate is 1.3-fold (0.12 log units) below it; measured number inside the range.
By their numbers in this assay, from the lowest: compound 2; then compounds 4 and 1 (each within the scatter of the next); then compound 3.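

Going by these compounds alone, this is the first pair here that differs in one place only. In this assay, putting 3,5-dimethylphenyl in place of 2,3-dimethylphenyl on the amine nitrogen in a ring gives a 1.1-fold lower number from compound 1 to compound 4 (0.03 log units; within the scatter), so rearranging the two methyl groups on this phenyl ring, with the same atoms and the rest of the molecule unchanged, makes no difference that this read-out can separate from ordinary repeat-to-repeat variation. The earlier compounds, each differing from compound 1 in more than one place, could not show this, and nothing measured here accounts for the result.

One pair covers only two arrangements of the same two methyl groups, so it says nothing yet about whether this part of the molecule would accept something quite different, such as a carboxylic acid, an amine or a longer chain like butyl on the phenyl ring. It also leaves open whether compound 2, with its lower number, owes that number to the groups on this ring or to the fluorine on the other phenyl ring, a question that only compounds changed in one of those places could settle.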